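A few compounds are considered here, and "the series" means these few. Any claim that something is new, unique, unknown or untested is made for them only; others in the source may bear on it.

Compound 3, `CC(C)=CCC1Cc2c(OC(=O)Nc3cccc(F)c3)cc(=O)n(CCCO)c2CC1(C)C`, stands second highest of the three compounds measured in a functional assay on PANC-1 cells (Homo sapiens) for inhibition, read by MTT assay, with a stated time of 24 h, tested at 10 uM (a lower number here means less inhibition, a higher number more inhibition at the concentration tested (going by the name of the read-out)), where compound 3 gives 66.1%. Its nearest neighbour is compound 1, `CCOc1cc(=O)n(CCCO)c2c1CC(CC=C(C)C)C(C)(C)C2`, for which compound 1 gives 66.5%; the step of a number 0.4 percentage points lower from compound 1 to compound 3 (within the scatter) lies within the scatter. Furthest away is compound 2, `CC(C)=CCOc1cc(=O)n(CCCO)c2c1CC(CC=C(C)C)C(C)(C)C2`, since compound 2 gives 20.7%, and the step of a number 45.4 percentage points higher from compound 2 to compound 3 (beyond the scatter) is large. Compound 4, `CC(C)=CCC1Cc2c(OC(=O)Nc3ccc(Cl)cc3)cc(=O)n(CCCO)c2CC1(C)C`, is not yet measured in this assay. It differs from compound 3 in one place: 4-chlorophenyl in place of 3-fluorophenyl on an amide-type nitrogen. Both measured steps that end at compound 3 concern what sits on the oxygen on the aromatic ring, not the ring on the amide-type nitrogen, so none of them bears directly on this change. With no step of this kind in hand, the change is expected to leave the read-out in this assay about where compound 3 stands, a step of a number 4.1 percentage points lower from compound 3 to compound 4 (within the scatter) within the scatter. Compound 4 is therefore estimated at 62%, with a range from 40% to 80%.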

Compound 4, a percentage reported as inhibition, at one concentration (the size of the read-out at that concentration, not a potency): 49.8%
Compound 4: the middle estimate sits 12.2 percentage points above what was measured, within the range that was stated.
By their numbers in this assay, from the lowest: compound 2; then compound 4; then compounds 3 and 1 (each within the scatter of the next).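

Within the data shown here, the ring on the amide-type nitrogen is not neutral in this assay: 4-chlorophenyl in place of 3-fluorophenyl gives a step of a number 16.3 percentage points lower from compound 3 to compound 4 (beyond the scatter), which the earlier steps, all at the oxygen on the aromatic ring, could not show. The match between the carbamoyl and ethyl groups on that oxygen therefore holds only for (3-fluorophenyl)carbamoyl, since (4-chlorophenyl)carbamoyl in place of ethyl gives a number 16.7 percentage points lower from compound 1 to compound 4 (beyond the scatter), while in place of 3-methylbut-2-en-1-yl it still gives a number 29.1 percentage points higher from compound 2 to compound 4 (beyond the scatter). Nothing at hand explains these differences.

The halogen and its place on the ring change together here, so the compounds shown cannot tell which of the two accounts for the step. From the compounds shown here alone, a 3-chlorophenyl or 4-fluorophenyl group on the same nitrogen would separate them, and how a plain phenyl group would read also remains open.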